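The compounds below may be only part of what the source reports. "The series", "measured", "known", "first", "only" and "open" are said of these compounds alone.

Compound 1 `COC1Cc2c(cnn2-c2ccccc2)C2(CCNCC2)O1`: in an assay for displacement of a labelled ligand from Sigma non-opioid intracellular receptor 1 (Cavia porcellus), read by scintillation counting, with a stated time of 180 min (on this read-out higher numbers stand for weaker inhibition and lower numbers for stronger inhibition), compound 1 gives > 1000 nM, which is a limit of the assay and not a number.
Compound 2 `COC1Cc2c(cnn2-c2ccccc2)C2(CCN(C(C)C)CC2)O1`: in this assay compound 2 gives 210 nM.

Compound 2 holds the only number shown in this assay; the other value is a limit. Compound 3 `C=C(C)CCN1CCC2(CC1)OC(OC)Cc1c2cnn1-c1ccccc1` differs from compound 2 by 3-methylbut-3-en-1-yl in place of isopropyl on an amine nitrogen in a ring. Within the data shown here, the one measured step at this nitrogen is an at least 4.7-fold lower number from compound 1 to compound 2 (0.67 log units; beyond the scatter), stated only as a bound because of the limit of > 1000 nM in this assay, at which 1 of the 2 values shown sits. Compound 3 keeps an alkyl group there, so a step toward a lower number of at most modest size, a 1.9-fold lower number from compound 2 to compound 3 (0.28 log units; within the scatter), is expected. For compound 3 the expected value in this assay is 110 nM, within 30 nM to 400 nM.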

Compound 3, inhibition constant: 1.6 nM
Compound 3: middle estimate off by 69-fold (1.84 log units), on the high side; the measured number lies below the stated range.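

Among these compounds, at this amine nitrogen, the choice of alkyl group matters far more than the earlier compounds could show: in this assay, the exchange of isopropyl for 3-methylbut-3-en-1-yl gives a 130-fold lower number from compound 2 to compound 3 (2.12 log units; beyond the scatter), so an alkyl group at this place does not by itself set the level. The full change from hydrogen gives an at least 620-fold lower number from compound 1 to compound 3 (2.79 log units; beyond the scatter), which is only a bound because the reading for compound 1 is a limit of the assay: the limit of > 1000 nM in this assay, at which 1 of the 3 values shown sits.

The compounds shown do not separate the longer chain of 3-methylbut-3-en-1-yl from its double bond. They also leave open how a saturated 3-methylbutyl chain or a benzyl group would read at this nitrogen.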